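This account rests on a few compounds, and the source may have more. Where it says the series, first, only, none or still open, it means among the compounds named here.

Compound 1 `CCNCC(=O)Nc1cc(OC)ccc1C(=O)c1ccc2c(c1)C=CC(C)(C)O2`: 6310 nM
Compound 2 `C=C(c1ccc(OC)cc1NC(=O)CN)c1ccc(OC)c2c1C=CC(C)(C)O2`: 780 nM

Both compounds were tested in a functional assay on MCF7 cells (Homo sapiens) for antiproliferative activity, read by MTT assay, with a stated time of 48 h; on this read-out higher numbers stand for weaker inhibition and lower numbers for stronger inhibition. Of the two, compound 2 has the lower number at 780 nM, and the gap to compound 1 at 6310 nM lies beyond the usual scatter, so compound 2 is the stronger inhibitor of this pair. These two compounds differ in more than one place, so their gap does not isolate any single change.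

Compound 3 `C=C(c1ccc(OC)cc1NC(=O)CN(C)C)c1ccc(OC)c2c1C=CC(C)(C)O2` keeps the structure of compound 2 except for one position, where dimethylamino stands in place of amino on a saturated chain carbon bound to a carbonyl carbon (dimethylamino in place of amino on a saturated chain carbon bound to a carbonyl carbon). Among the compounds with values here, no measured pair shows this change, so the expectation is tentative. The estimated 1.2-fold higher number from compound 2 to compound 3 (0.06 log units; within the scatter) in this assay is small, towards weaker inhibition, and may stay within the scatter. The expected value for compound 3 is 900 nM, with a range of 300 nM to 2500 nM.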

Compound 3, half-maximal inhibitory concentration: 2580 nM
Estimate against measurement, compound 3: 2.9-fold (0.46 log units) below; measured number outside the range, above it.
By their numbers in this assay, from the lowest: compound 2; then compound 3; then compound 1.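

In this assay, within the data shown here, putting dimethylamino in place of amino on a saturated chain carbon bound to a carbonyl carbon gives a 3.3-fold higher number from compound 2 to compound 3 (0.52 log units; beyond the scatter) and so provides the first reading of a change made in one place alone. The step is modest, yet it lies beyond the scatter, so in this pair the position does respond to the swap, and the direction is towards weaker inhibition. Nothing measured here accounts for this step.

The compounds shown leave open whether methylamino at this position would stay with amino or go with dimethylamino, and whether a ring amine such as pyrrolidine or morpholine would be tolerated there. Compound 1 differs from both other compounds in more than one place, so it cannot settle either question.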